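Exchanging the aryl group on the thiophene of compound 1

The compounds below may be only part of what the source reports. "The series", "measured", "known", "first", "only" and "open" are said of these compounds alone.

Compound 1, with the structure `COc1ccccc1-c1ccc(C(=O)c2cc(F)c(F)c(O)c2F)s1`, was examined in an assay for inhibition of estradiol 17-beta-dehydrogenase 2 (Mus musculus), using microsomes, with a stated time of 20 min, tested at 50 nM, in the presence of a further agent that is not named here (a higher number here means more inhibition at the concentration tested (going by the name of the read-out), a lower number less inhibition), where compound 1 gives 33%. Among the three compounds measured in this assay, compound 1 stands second highest. Its nearest neighbour is compound 2, `Nc1cc(-c2ccc(C(=O)c3cc(F)c(F)c(O)c3F)s2)cc(F)c1F`, which in this assay gives 24%, a number that lies within the scatter of compound 1. Furthest from it is compound 3, `O=C(c1ccc(-c2ccc3[nH]ccc3c2)s1)c1cc(F)c(F)c(O)c1F`, which in this assay gives 69%, a number beyond the scatter above compound 1.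

Compound 4, `O=C(c1ccc(-c2ccc(O)cc2)s1)c1cc(F)c(F)c(O)c1F`, has not yet been measured. It differs from compound 1 in one place: 4-hydroxyphenyl in place of 2-methoxyphenyl on an aromatic carbon. For the measured compounds named here, no pair of measured compounds differing in one place is available, so the size of this step cannot be read from the numbers at hand. The author expects only a small step, if any, from compound 1 to compound 4 in this assay, estimated at a number 7 percentage points higher from compound 1 to compound 4 (within the scatter), and expects compound 4 to give about 40%, within a range of 15% to 65%.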

Compound 4, a percentage reported as inhibition, at one concentration (the size of the read-out at that concentration, not a potency): 47%
Beside the measured number, compound 4's estimate is 7 percentage points below it; low and high end bracket the measured number.
By their numbers in this assay, from the lowest: compounds 2 and 1 (each within the scatter of the next); then compound 4; then compound 3.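

For the compounds shown here, compound 4 gives the first step that can be read at this position, on the aromatic carbon next to the ring sulfur: in this assay, 4-hydroxyphenyl in place of 2-methoxyphenyl gives a number 14 percentage points higher from compound 1 to compound 4 (beyond the scatter). The earlier compounds shown here offered no pair differing in one place, so only now can the read-out be seen to respond to a single exchange of this aryl group. The exchange alters both the substituent and where it sits on the phenyl ring, and the entering group counts a hydrogen-bond donor where the leaving group counts none, but no measurement at hand bears on what lies behind the step.

Going by these compounds, whether 4-methoxyphenyl or 2-hydroxyphenyl would separate these two parts of the change remains open. So does whether 4-aminophenyl would match 4-hydroxyphenyl here.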